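The source may hold more compounds than are shown below. What is called first, only, known or untested is meant among the compounds shown, and "the series" means these compounds.

Series notes.

Compound 1 `CCCCCCOc1ccc(-c2c(C)[nH]c(=O)n2C)cc1`: in a functional assay on brain (Rattus norvegicus, strain Wistar) for inhibition (on this read-out lower numbers stand for stronger inhibition and higher numbers for weaker inhibition), compound 1 gives 7300 nM.
Compound 2 `CCCCCCCOc1ccc(-c2c(C)[nH]c(=O)n2C)cc1`: in this assay compound 2 gives 5700 nM.
Compound 3 `Cc1[nH]c(=O)n(C)c1-c1ccc(OCc2ccccc2)cc1`: in this assay compound 3 gives 6700 nM.

Compound 3 holds the second highest of the three numbers, but all three sit within the scatter of one another: a 1.1-fold lower number from compound 1 to compound 3 (0.04 log units; within the scatter), a 1.2-fold higher number from compound 2 to compound 3 (0.07 log units; within the scatter), and a 1.3-fold lower number from compound 1 to compound 2 (0.11 log units; within the scatter). No order among them can be read from these values.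

Compound 4 `Cc1[nH]c(=O)n(C2CCCCC2)c1-c1ccc(OCc2ccccc2)cc1` is the next compound to be measured. It differs from compound 3 by cyclohexyl in place of methyl on an aromatic nitrogen. For the measured compounds named here, every measured step so far alters the group attached to the oxygen on the aromatic ring, and each of those steps lies within the scatter. Going by the values given here, none of them touches the aromatic nitrogen of the five-membered aromatic ring, so no measured step bears on this change, and its direction is unknown.

With nothing in the series to lean on, the estimate for compound 4 is set close to where compound 3 stands because compound 3 gives 6700 nM, and the range is kept wide. Compound 4 is expected to give about 6000 nM, between 1500 nM and 25000 nM. The step this estimate implies for compound 4 is a 1.1-fold lower number from compound 3 to compound 4 (0.05 log units; within the scatter).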

Compound 4, half-maximal inhibitory concentration: 8300 nM
For compound 4 the middle estimate is 1.4-fold (0.14 log units) below the measured one, and the stated range covers the measured number.
By their numbers in this assay, from the lowest: compounds 2, 3, 1 and 4 (each within the scatter of the next).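

For the compounds shown here, this is the first measured change on the aromatic nitrogen of the five-membered aromatic ring: in this assay, a 1.2-fold higher number from compound 3 to compound 4 (0.09 log units; within the scatter) is the step for cyclohexyl in place of methyl, and it lies within the scatter. Six heavy atoms and a six-membered non-aromatic ring of carbon only thus replace one heavy atom at this nitrogen, with the group on the oxygen kept as in compound 3, and this read-out does not separate the two groups. Nothing available explains this result or ties it to any property of either group.

The series shown holds only methyl and cyclohexyl on this nitrogen, both with one group on the oxygen, so it remains open whether the same exchange reads alike with the hexyl or heptyl chain of compound 1 or compound 2 on the oxygen. Also open, on these data alone, is how the number responds to a bare hydrogen on this nitrogen, or to a chain there ending in an amine or a carboxylic acid.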